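Notes on the aryl swap from compound 2 to compound 3

The source may hold more compounds than are shown below. What is called first, only, known or untested is meant among the compounds shown, and "the series" means these compounds.

In an assay on RPMI-8866 cells for inhibition of integrin alpha-4/beta-1 (Homo sapiens) (on this read-out lower numbers stand for stronger inhibition and higher numbers for weaker inhibition), compound 2 `O=C(O)C[C@@H](NC(=O)[C@@H]1CCN1S(=O)(=O)c1cc(Cl)cc(Cl)c1)c1ccc(Br)cc1` gives 2.1 nM. Among the compounds with values here, that is the higher of the two numbers measured so far. Compound 1 `O=C(O)C[C@@H](NC(=O)[C@@H]1CCN1S(=O)(=O)c1cc(Cl)cc(Cl)c1)c1ccc(OC2CC2)cc1` gives 0.31 nM in this assay. Within the data shown here, the single measured step is a 6.8-fold higher number from compound 1 to compound 2 (0.83 log units; beyond the scatter), bromo in place of cyclopropyloxy on an aromatic carbon.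

Compound 3 `COc1ccc([C@@H](CC(=O)O)NC(=O)[C@@H]2CCN2S(=O)(=O)c2cc(Cl)cc(Cl)c2)cn1` is not yet measured. The change from compound 2 is 6-methoxypyridin-3-yl in place of 4-bromophenyl on a saturated chain carbon bound to an amide-type nitrogen and a saturated chain carbon. It bears on the step above: the bromo goes out and an alkoxy group returns, though as methoxy rather than cyclopropyloxy, and the ring now carries a nitrogen. Among the measured compounds shown here, no measured pair separates these two parts of the change. A lower number is therefore expected for compound 3, somewhat smaller in size than the step above reversed, as a 2.1-fold lower number from compound 2 to compound 3 (0.32 log units; beyond the scatter). The estimate for compound 3 in this assay is 1 nM, within 0.3 nM to 3.5 nM.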

Compound 3, half-maximal inhibitory concentration: 3 nM
Beside the measured number, compound 3's estimate is 3.0-fold (0.48 log units) below it, within the range that was stated.
By their numbers in this assay, from the lowest: compound 1; then compounds 2 and 3 (each within the scatter of the next).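

In this assay, 6-methoxypyridin-3-yl in place of 4-bromophenyl on the saturated chain carbon bound to an amide-type nitrogen and a saturated chain carbon leaves the two compounds within the scatter (a 1.4-fold higher number from compound 2 to compound 3 (0.15 log units; within the scatter)). Against the 4-(cyclopropyloxy)phenyl group at the same place, the step is beyond the scatter (a 9.7-fold higher number from compound 1 to compound 3 (0.99 log units; beyond the scatter)), so the methoxy group on the pyridine ring does not restore the low number seen with cyclopropyloxy on the phenyl ring. No measurement at hand gives a reason for either step.

The part played by the ring nitrogen and the part played by methoxy in place of cyclopropyloxy remain unseparated. A 4-methoxyphenyl group or a 6-(cyclopropyloxy)pyridin-3-yl group at this place would tell these two parts apart.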